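Thiophene for Phenyl in a Nucleoside Cytotoxicity Series

The source may report more compounds than this note shows. Statements on the series, on what has been measured and on what is new or still open speak of the compounds shown alone.

Measured so far in an ADME assay on MRC5 cells (Homo sapiens), read by MTT assay, with a stated time of 72 h; on this read-out higher numbers stand for weaker inhibition and lower numbers for stronger inhibition:
compound 1 `C#Cc1cn([C@@H]2O[C@H](CO)[C@@H](O)[C@H]2O)c2ncnc(C)c12`: 1440 nM
compound 2 `CN(C)c1ncnc2c1c(-c1ccoc1)cn2[C@@H]1O[C@H](CO)[C@@H](O)[C@H]1O`: > 100000 nM
compound 3 `COc1nc(N)nc2c1c(-c1ccccc1)cn2[C@@H]1O[C@H](CO)[C@@H](O)[C@H]1O`: > 100000 nM

Of these three, only compound 1 returns a number in this assay. Compound 2 returns only a limit of the assay, not a number. Compound 3 likewise returns only a limit of the assay, so its position on the scale is known just as a boundary. Compound 3 thus stands at the weak end of what this assay can report, together with compound 2 (the limit of > 100000 nM in this assay, at which 2 of the 3 values shown sit). Among the compounds with values here, no step between two measured compounds differing in one place is available, so no measured change can be pointed to.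

Compound 4 `COc1nc(N)nc2c1c(-c1cccs1)cn2[C@@H]1O[C@H](CO)[C@@H](O)[C@H]1O` differs from compound 3 in one place (thiophen-2-yl in place of phenyl on an aromatic carbon). Since compound 3 itself sits at a limit, the step from compound 3 to compound 4 in this assay is expected to be none beyond the usual scatter, a number no higher from compound 3 to compound 4 (the limit leaves the size open). Compound 4 is therefore estimated at 100000 nM, with a range from 30000 nM to 300000 nM, and is expected most likely to be reported again as a limit rather than a number.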

Compound 4, half-maximal inhibitory concentration: > 100000 nM
Compound 4: a limit, no number (the forecaster's own chance of this, stated with the estimate: 75%); the middle value sits exactly at the limit.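

Compound 3 and compound 4 both return only a limit in this assay, so the exchange of phenyl for thiophen-2-yl cannot be read as a step: the limit of > 100000 nM in this assay, at which 3 of the 4 values shown sit.

The compounds shown leave open where either compound would fall if a number could be reported.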